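This account rests on a few compounds, and the source may have more. Where it says the series, first, only, none or still open, it means among the compounds named here.

Measured in a functional assay on HT-1080 cells (Homo sapiens) for antiproliferative activity, read by sulforhodamine B assay, with a stated time of 48 h; on this read-out higher numbers stand for weaker inhibition and lower numbers for stronger inhibition:
compound 1 `CCNC(=O)Nc1ccc(S(=O)(=O)Oc2ccccc2C(C)C)cc1` gives 250 nM
compound 2 `CCNC(=O)Nc1ccc(S(=O)(=O)Oc2ccccc2I)cc1` gives 140 nM
compound 3 `CCCNC(=O)Nc1ccc(S(=O)(=O)Oc2ccccc2C(C)C)cc1` gives 680 nM

Compound 4 `CCCNC(=O)Nc1ccc(S(=O)(=O)Oc2ccccc2I)cc1` has not yet been measured in this assay. It differs from compound 3 by iodo in place of isopropyl on an aromatic carbon. The same change runs from compound 1 to compound 2, where it gave a 1.8-fold lower number from compound 1 to compound 2 (0.25 log units; within the scatter); the place of the change is described in the same words for both pairs, so it is the same change. The cores of compound 1 and compound 3 differ by methyl in place of hydrogen on a saturated chain carbon, two bonds along the chain from an amide-type nitrogen, which gave a 2.7-fold higher number from compound 1 to compound 3 (0.43 log units; beyond the scatter). Compound 3 stands at the highest number of the three measured compounds. Within the data shown here, only one earlier instance of the change is at hand, and that one lies within the scatter, so a small downward step or no change at all is expected. The step is expected to be a 1.8-fold lower number from compound 3 to compound 4 (0.25 log units; within the scatter), which rests on a 1.8-fold lower number from compound 1 to compound 2 (0.25 log units; within the scatter). For compound 4 the estimate in this assay is 380 nM, with a range from 180 nM to 800 nM.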

Compound 4, half-maximal inhibitory concentration: 700 nM
Beside the measured number, compound 4's estimate is 1.8-fold (0.27 log units) below it, within the range that was stated.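

In this assay iodo in place of isopropyl gives a 1.0-fold higher number from compound 3 to compound 4 (0.01 log units; within the scatter), and the two instances of this change do not differ beyond the scatter: the same change on two cores in this assay, a 1.8-fold lower number (0.25 log units; within the scatter) from compound 1 to compound 2 and a 1.0-fold higher number (0.01 log units; within the scatter) from compound 3 to compound 4, 1.8-fold (0.26 log units) apart, within the scatter of two such steps. Methyl in place of hydrogen on the chain gives a 5.0-fold higher number from compound 2 to compound 4 (0.70 log units; beyond the scatter), and this change also carries across the two cores: the same change on two cores in this assay, a 2.7-fold higher number (0.43 log units; beyond the scatter) from compound 1 to compound 3 and a 5.0-fold higher number (0.70 log units; beyond the scatter) from compound 2 to compound 4, 1.8-fold (0.26 log units) apart, within the scatter of two such steps. These four compounds show the two changes carrying over between these cores, but with only two instances of each in one assay, they do not show that either change would carry to other cores in the series.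

Still open, as far as these compounds go, is whether a nitrile or a methoxy group in place of iodo would follow the same pattern. Also open, from the compounds shown here alone, is whether a longer chain on the amide-type nitrogen would continue the step seen with methyl.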